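Removing tert-butoxycarbonyl from compound 2

This account rests on a few compounds, and the source may have more. Where it says the series, first, only, none or still open, it means among the compounds named here.

In an ADME assay on Vero cells (Chlorocebus sabaeus) for cytotoxicity, read by MTT assay (a lower number here means that less compound is tolerated, a higher number that more compound is tolerated), compound 1 (`Cn1nc(C(F)(F)F)cc1C(=O)Nc1ccc(S(=O)(=O)N2CCOCC2)cc1`) gives > 300000 nM as a limit of the assay. Compound 2 (`Cn1nc(C(F)(F)F)cc1C(=O)Nc1ccc(S(=O)(=O)N2CCN(C(=O)OC(C)(C)C)CC2)cc1`) gives > 300000 nM as a limit too. Compound 2 thus offers no exact number (the limit of > 300000 nM in this assay, at which 2 of the 2 values shown sit) to start from. Compound 3 (`Cn1nc(C(F)(F)F)cc1C(=O)Nc1ccc(S(=O)(=O)N2CCNCC2)cc1`) carries hydrogen in place of tert-butoxycarbonyl on an amine nitrogen in a ring and awaits measurement. Among the measured compounds shown here, with no measured step as a guide, a small downward move or none beyond the scatter is expected in this assay here, estimated as an at least 1.3-fold lower number from compound 2 to compound 3 (0.13 log units; that floor lies within the scatter) in size. Compound 3 is estimated at 220000 nM with an expected range of 80000 nM to 300000 nM overall.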

Compound 3, half-maximal cytotoxic concentration: 126000 nM
For compound 3 the middle estimate is 1.7-fold (0.24 log units) above the measured one; the measured number falls inside the stated range.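

In this assay, compound 3 gives the only exact number among the compounds shown, so this ring nitrogen is a place where a change can move the read-out. Hydrogen in place of tert-butoxycarbonyl gives an at least 2.3-fold lower number from compound 2 to compound 3 (0.37 log units; beyond the scatter), and piperazin-1-yl in place of morpholin-4-yl gives an at least 2.3-fold lower number from compound 1 to compound 3 (0.37 log units; beyond the scatter). Both steps are lower bounds on the true size of the change: the limit of > 300000 nM in this assay, at which 2 of the 3 values shown sit.

The compounds shown leave open how far each step actually reaches. They also leave open whether a methyl or acetyl group on that nitrogen would keep the number at the limit or lower it as hydrogen does.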